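A few compounds are considered here, and "the series" means these few. Any claim that something is new, unique, unknown or untested is made for them only; others in the source may bear on it.

Measured compounds:
compound 1, `C[C@@H]1CN(c2sc(CO)nc2-c2nc3ccccc3[nH]2)CCN1C(=O)Cn1cnc2cccnc21`: > 10000 nM
compound 2, `CCc1ncc(-c2nc(C(F)(F)F)sc2N2CCN(C(=O)Cn3nc(C)nc3C)[C@H](C)C2)cn1`: 1430 nM

Of the compounds shown here, two have been tested in a functional assay on U2OS cells for antagonist activity at C-X-C chemokine receptor type 3 (Homo sapiens), read by beta-arrestin recruitment; a higher number here means a weaker inhibitor, a lower number a stronger inhibitor. For compound 1 the result is only a limit, > 10000 nM; this is the limit of > 10000 nM in this assay, at which 1 of the 2 values shown sits. Compound 2 gives 1430 nM, the only number shown, and it is therefore the single measured point from which the step to compound 3 is judged. Compound 3, `CCOc1ccc(-c2nc(C(F)(F)F)sc2N2CCN(C(=O)Cn3nc(C)nc3C)[C@H](C)C2)cn1`, has not yet been tested. It differs from compound 2 in one place: 6-ethoxypyridin-3-yl in place of 2-ethylpyrimidin-5-yl on an aromatic carbon. For the measured compounds named here, no step between measured compounds exists here, so the size of such a change cannot be read from any pair in this set. Both the leaving and the entering group are one six-membered aromatic ring, and the step is expected to be small, a 1.4-fold lower number from compound 2 to compound 3 (0.16 log units; within the scatter), probably within the scatter. Compound 3 is accordingly estimated at 1000 nM, with a range from 300 nM to 4000 nM.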

Compound 3, half-maximal inhibitory concentration: 505 nM
Compound 3: the middle estimate sits 2.0-fold (0.30 log units) above what was measured, and the stated range covers the measured number.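

In this assay, for the compounds shown here, replacing 2-ethylpyrimidin-5-yl with 6-ethoxypyridin-3-yl gives a 2.8-fold lower number from compound 2 to compound 3 (0.45 log units; beyond the scatter), the first step in this set that can be read. It shows that this position, on an aromatic carbon next to the ring nitrogen, responds to the exchange of one six-membered aromatic ring for another, even though both groups carry the same count of hydrogen-bond acceptors and no net charge. Nothing measured here accounts for the direction of this step.

The compounds shown leave open whether the step follows from the change of ring or from the change of substituent, as the two groups differ in both. A 2-ethoxypyrimidin-5-yl or a 6-ethylpyridin-3-yl group at this position would bear on that question, and a 6-aminopyridin-3-yl group would extend it to an amine.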